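A Second Hydroxyl on the Side-Chain Amide

This account rests on a few compounds, and the source may have more. Where it says the series, first, only, none or still open, it means among the compounds named here.

compound 1 `CC(C)(C)c1nc2ccc(NCc3cccc(C(F)(F)F)c3)cc2n(CCNC(=O)CO)c1=O`: > 3000 nM
compound 2 `Cc1nc2ccc(NCc3cccc(C(F)(F)F)c3)cc2n(CCNC(=O)[C@H](C)O)c1=O`: 8000 nM

Of the compounds shown here, two have been tested in an assay for inhibition of acyl-CoA desaturase 1 (Rattus norvegicus), using microsomes; a lower number here means a stronger inhibitor, a higher number a weaker inhibitor. Compound 1 gives > 3000 nM, which is a limit of the assay and not a number (the limit of > 3000 nM in this assay, at which 1 of the 2 values shown sits). Compound 2 gives 8000 nM in this assay, and this is the only number shown, so compound 2 stands alone and no measured step can be drawn from it.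

Compound 3 `Cc1nc2ccc(NCc3cccc(C(F)(F)F)c3)cc2n(CCNC(=O)C(O)CO)c1=O` has not yet been measured. It differs from compound 2 in one place: 1,2-dihydroxyethyl in place of 1-hydroxyethyl on a carbonyl carbon. The change is confined to the short chain on the carbonyl carbon whose other neighbour is the amide-type nitrogen, with the rest of the molecule kept the same.

For the measured compounds named here, with no measured step to lean on, the expected step from compound 2 to compound 3 is small, no change at the digits printed from compound 2 to compound 3 (within the scatter), in no particular direction and within the usual scatter. Compound 3 is therefore estimated at 8000 nM, between 3000 nM and 20000 nM.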

Compound 3, half-maximal inhibitory concentration: 268 nM
Estimate against measurement, compound 3: 30-fold (1.47 log units) above; measured number outside the range, below it.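

The short chain on the carbonyl carbon matters in this assay: putting 1,2-dihydroxyethyl in place of 1-hydroxyethyl gives a 30-fold lower number from compound 2 to compound 3 (1.47 log units; beyond the scatter) with the rest of the molecule kept the same. The change looks small on paper, with 3 heavy atoms leaving and 4 entering, so a minor edit at this position can move the number well beyond the scatter. No measurement shown here explains why this step is so large.

As far as these compounds go, the 1-hydroxyethyl of compound 2 has a defined stereocentre, whereas the 1,2-dihydroxyethyl of compound 3 is drawn without one, so the role of spatial arrangement at this carbon remains open. From the compounds shown here alone, it is also open whether a longer chain carrying further hydroxyl groups, an amine or a carboxylic acid at this position would do better or worse than the 1,2-dihydroxyethyl group.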